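Sulfonyl substituent in the anilino series: methylsulfonyl to sulfamoyl

A few compounds are considered here, and "the series" means these few. Any claim that something is new, unique, unknown or untested is made for them only; others in the source may bear on it.

Measured compounds:
compound 1 `Clc1cccc(Cl)c1Nc1nc2c(Nc3ccccc3)ncnc2s1`, 176 nM
compound 2 `CS(=O)(=O)c1ccc(Nc2ncnc3sc(Nc4c(Cl)cccc4Cl)nc23)cc1`, 5 nM

In a functional assay on HEK293 cells for antagonist activity at transient receptor potential cation channel subfamily V member 1 (Homo sapiens), read by calcium flux (on this read-out higher numbers stand for weaker inhibition and lower numbers for stronger inhibition), compound 2 gives 5 nM, the lowest of the two numbers recorded; the nearest is compound 1 with 176 nM. Among the compounds with values here, the one step in hand, a 35-fold lower number from compound 1 to compound 2 (1.55 log units; beyond the scatter), shows that the substituent at this position weighs heavily on the read-out.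

Compound 3 `NS(=O)(=O)c1ccc(Nc2ncnc3sc(Nc4c(Cl)cccc4Cl)nc23)cc1` differs from compound 2 by amino in place of methyl on a sulfonyl sulfur. Within the data shown here, no measured step covers this exchange; the step from compound 1 to compound 2 only tells that the sulfonyl group itself is the active change, not how its other substituent acts. The sulfonyl stays in place, so a small step in this assay is expected, within the scatter, and the direction cannot be set from the data. For compound 3 the estimate is 6 nM, range 2 nM to 20 nM, that is a 1.2-fold higher number from compound 2 to compound 3 (0.08 log units; within the scatter).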

Compound 3, half-maximal inhibitory concentration: > 5000 nM
Compound 3 was reported as a limit (the forecaster's own chance of this, stated with the estimate: 2%); middle value at least 830-fold (2.92 log units) away from the limit.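

In this assay compound 3 gives > 5000 nM, which is a limit of the assay and not a number. The sulfonyl group alone therefore does not secure strong inhibition at this position: the substituent on the sulfonyl sulfur decides the outcome, with amino in place of methyl giving an at least 1000-fold higher number from compound 2 to compound 3 (3.00 log units; beyond the scatter). Sulfamoyl also moves the read-out in the opposite direction to methylsulfonyl when each is compared with hydrogen on the aromatic carbon, giving an at least 28-fold higher number from compound 1 to compound 3 (1.45 log units; beyond the scatter).

From the compounds shown here alone, the full size of both steps stays unknown, since each rests on the limit. Also open, going by these compounds, is whether ethyl, methylamino or dimethylamino on the sulfonyl sulfur would track with methyl or with amino, and whether a methylsulfonyl replacement such as a nitrile would hold the read-out of compound 2.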